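Vero cell cytotoxicity: fluoro in place of the amide-acid chain

A few compounds are considered here, and "the series" means these few. Any claim that something is new, unique, unknown or untested is made for them only; others in the source may bear on it.

compound 1, `CN1CCN(CC(=O)Nc2ccc(-c3nc4cc(Cl)c(Cl)cc4[nH]3)cc2)CC1`: > 100000 nM
compound 2, `O=C(O)CCC(=O)Nc1ccc(-c2nc3cc(C(F)(F)F)ccc3[nH]2)cc1`: > 100000 nM
compound 3, `O=C(CN1CCCC1)Nc1ccc(-c2nc3ccccc3[nH]2)cc1`: > 100000 nM

Three compounds of the series have been run in an ADME assay on Vero cells (Chlorocebus sabaeus) for cytotoxicity; a higher number here means that more compound is tolerated, a lower number that less compound is tolerated. For compound 1 the value > 100000 nM is a limit of the assay, not a number. Compound 2 gives > 100000 nM, again a limit. Compound 3 gives > 100000 nM, also a limit. For the measured compounds named here, compound 2 therefore stands where every measured compound stands, namely at the limit of > 100000 nM in this assay, at which 3 of the 3 values shown sit; no measured compound is separated from another, and no ordering within the set can be drawn.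

Compound 4, `Fc1ccc(-c2nc3cc(C(F)(F)F)ccc3[nH]2)cc1`, is not yet measured. It differs from compound 2 in one place: fluoro in place of ((2-carboxyethyl)carbonyl)amino on an aromatic carbon. Going by the values given here, no step between two measured compounds is available to size this change in this assay, and the measured values give only limits. The step from compound 2 to compound 4 is estimated as an at least 1.6-fold lower number from compound 2 to compound 4 (0.22 log units; that floor lies within the scatter), a small move toward less tolerance at most, with a fair chance that the limit is reached again. Compound 4 is expected to give 60000 nM, with a range from 15000 nM to 150000 nM.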

Compound 4, half-maximal cytotoxic concentration: 60000 nM
Beside the measured number, compound 4's estimate shows no gap at the digits printed; low and high end bracket the measured number.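

In this assay, for the compounds shown here, compound 4 is the first compound of the series to give a number rather than a limit, so a value can be read once the ((2-carboxyethyl)carbonyl)amino chain on this aromatic carbon gives way to fluoro. The change gives an at least 1.6-fold lower number from compound 2 to compound 4 (0.22 log units; that floor lies within the scatter), and because that figure is only a floor, the true step may be larger. The other compounds carry no such number and stay unseparated: the limit of > 100000 nM in this assay, at which 3 of the 4 values shown sit.

The compounds shown leave open how large the step really is, and whether it follows from the loss of the chain or from the entry of fluoro. A chloro, a methoxy or a simple amine at this place on the same core would help to separate these two readings.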